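A Larger Group on the Ring Nitrogen of Compound 1

A few compounds are considered here, and "the series" means these few. Any claim that something is new, unique, unknown or untested is made for them only; others in the source may bear on it.

Among the compounds with values here, compound 1 `CC(C)c1onc(-c2c(Cl)cccc2Cl)c1COc1ccc(-c2nc3ccc(C(=O)O)cc3n2C(C)C)cc1` is the only member of this set with a number: in an assay on isolated protein for agonist activity at Bile acid receptor (Homo sapiens), read by TR-FRET (on this read-out lower numbers stand for an effect already at smaller amounts and higher numbers for an effect only at larger amounts of compound), compound 1 gives 56.7 nM. Compound 2 `CC(=O)C1CCC(Cn2c(-c3ccc(OCc4c(-c5c(Cl)cccc5Cl)noc4C(C)C)cc3)nc3ccc(C(=O)O)cc32)CC1` belongs to the same series, but in this assay compound 2 gives "not determined" (no result reported), so no result is available for it. Compound 3 `CC(C)c1onc(-c2c(Cl)cccc2Cl)c1COc1ccc(-c2nc3ccc(C(=O)O)cc3n2CC2CCCCC2)cc1` differs from compound 1 by cyclohexylmethyl in place of isopropyl on an aromatic nitrogen. Within the data shown here, no step between measured compounds exists to guide the expectation, so its size rests on judgement alone. For compound 3 a step of a 1.3-fold lower number from compound 1 to compound 3 (0.10 log units; within the scatter) is expected, no larger than the usual scatter. Compound 3 is therefore estimated at 45 nM in this assay, with a range from 12 nM to 180 nM.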

Compound 3, half-maximal effective concentration: 19.9 nM
Estimate against measurement, compound 3: 2.3-fold (0.35 log units) above, and the stated range covers the measured number.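

On the aromatic nitrogen, in this assay, cyclohexylmethyl in place of isopropyl gives a 2.8-fold lower number from compound 1 to compound 3 (0.45 log units; beyond the scatter), so this position accepts a larger group with a six-membered non-aromatic ring of carbon only, and the number falls rather than rises. No measurement at hand bears on the cause of this step. The step to compound 2 cannot be read. Going by these compounds, whether a longer chain, a phenyl ring, or an amine on the cyclohexyl ring would lower the number further remains open.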